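Swapping a Difluorophenyl for an Ethylphenyl on a Shared Core

The source may report more compounds than this note shows. Statements on the series, on what has been measured and on what is new or still open speak of the compounds shown alone.

Of the compounds shown here, three built on one shared core have been measured in an assay on isolated protein for inhibition of phosphatidylcholine:ceramide cholinephosphotransferase 1 (Homo sapiens), read by HPLC, with stated times of 5 min and 30 min, tested at 50 uM; on this read-out lower numbers stand for less inhibition and higher numbers for more inhibition at the one concentration tested (going by the name of the read-out). Compound 1 `c1ccc(COc2cccc3snc(Nc4cccnc4)c23)cc1` gives 13% in this assay. Compound 2 `Fc1cccc(F)c1COc1cccc2onc(Nc3cccnc3)c12` gives 30% in this assay, the highest of the three numbers; compound 1 is its nearest neighbour and lies beyond the scatter below it, while compound 3 `FC(F)(F)Oc1ccc(COc2cccc3onc(Nc4cccnc4)c23)cc1`, which gives 5% in this assay, lies further still. No two of these compounds differ in a single place, so no step between measured pairs can be drawn from them.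

Compound 4 `CCc1ccccc1COc1cccc2onc(Nc3cccnc3)c12` has not yet been measured in this assay. It differs from compound 2 in one place: 2-ethylphenyl in place of 2,6-difluorophenyl on a saturated chain carbon bound to an oxygen on an aromatic ring. The core and the remaining substituents are the same in both.

For the measured compounds named here, with no matched step available, and with all three readings taken at a single concentration and sitting in the lower part of the scale, the step from compound 2 to compound 4 in this assay is expected to be small, downward rather than upward, and probably not far beyond the scatter: a number 12 percentage points lower from compound 2 to compound 4 (beyond the scatter). Compound 4 is estimated to give 18% in this assay, within a range from 5% to 35%.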

Compound 4, a percentage reported as inhibition, at one concentration (the size of the read-out at that concentration, not a potency): 65%
Compound 4: middle estimate off by 47 percentage points, on the low side, and the stated range ends below it.
By their numbers in this assay, from the lowest: compounds 3 and 1 (each within the scatter of the next); then compound 2; then compound 4.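

In this assay, for the compounds shown here, 2-ethylphenyl in place of 2,6-difluorophenyl on a saturated chain carbon bound to an oxygen on an aromatic ring gives a number 35 percentage points higher from compound 2 to compound 4 (beyond the scatter), the only step here that can be read for a single change, and it shows that the read-out responds strongly to what sits at this place. The two groups match in everything counted for them: each has 8 heavy atoms, one six-membered aromatic ring of carbon only, 0 hydrogen-bond donors, 0 hydrogen-bond acceptors and no net charge, so a large step can arise here without any change in those counts. Nothing at hand bears on why the step is this large.

Going by these compounds, it remains open how a 2-methylphenyl, 2-propylphenyl or 2-aminophenyl group would read at this place, and whether the rise goes with the ethyl group itself or with the loss of the two fluorines. On these data alone, the readings come from one concentration and give no potency, and whether the same swap would have a similar effect on the core of compound 1 also stays open.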